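A Second Chloro on the Phenyl Ring

The source may report more compounds than this note shows. Statements on the series, on what has been measured and on what is new or still open speak of the compounds shown alone.

Compound 1: `N=C(NCCCc1c[nH]cn1)NCCC(c1ccc(F)cc1)c1ccccn1` gives 7.94
Compound 2: `N=C(NCCCc1c[nH]cn1)NCCC(c1ccc(Cl)cc1)c1ccccn1` gives 7.39

These two compounds share one core and differ only in the group on the phenyl ring; both were tested in a functional assay on muscle tissue for agonist activity at histamine H2 receptor (Cavia porcellus); a higher number here means a more potent compound, by a factor of ten per unit of this negative logarithm, a lower number a less potent compound. Going by the values given here, compound 2 stands lowest of the two numbers: the single measured step, a number 0.55 log units lower from compound 1 to compound 2 (beyond the scatter), reads as a loss of potency when chloro replaces fluoro.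

The unmeasured compound 3, `N=C(NCCCc1c[nH]cn1)NCCC(c1ccc(Cl)c(Cl)c1)c1ccccn1`, takes the core of compound 2 one step further: chloro in place of hydrogen on an aromatic carbon. The new chloro sits on an aromatic carbon of the six-membered carbon ring, ortho to the chloro group already present, so that a 4-chlorophenyl becomes a 3,4-dichlorophenyl.

Among the compounds with values here, only one step bears on this. The exchange that produced compound 2 from compound 1 cost potency beyond the scatter, which suggests that this part of the molecule is sensitive to what is placed on the phenyl ring. Adding a second chloro is a different change, though, and no measured pair shows it directly. On that basis compound 3 is expected to lie somewhat below compound 2, a step estimated as a number 0.39 log units lower from compound 2 to compound 3 (beyond the scatter). The estimate for compound 3 is therefore 7, with a likely range from 6.4 to 7.6.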

Compound 3, negative logarithm of the half-maximal effective concentration: 7.54
For compound 3 the middle estimate is 0.54 log units below the measured one; the measured number falls inside the stated range.
By their numbers in this assay, from the lowest: compounds 2 and 3 (each within the scatter of the next); then compound 1.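

In this assay the added chloro gives a number 0.15 log units higher from compound 2 to compound 3 (within the scatter), so on this evidence a 3,4-dichlorophenyl cannot be told apart from a 4-chlorophenyl. The earlier step exchanged one group for another at a single place on the phenyl ring, whereas this one fills a position that carried only hydrogen, ortho to a chloro group, and the potency reading holds within the usual spread of repeat measurements. The gap to the fluoro compound remains, at a number 0.40 log units lower from compound 1 to compound 3 (beyond the scatter), so a second chloro does not bring the number back to that of the 4-fluorophenyl.

Nothing measured here accounts for these readings, so the result stands as an observation without an explanation. Open still is whether a methoxy, a trifluoromethyl or an amine in place of this new chloro would keep the number in the same range, and whether a second fluoro at the same place on the 4-fluorophenyl would match what the chloro does on the 4-chlorophenyl.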